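Removing the para chloro: compound 3 to compound 4

A few compounds are considered here, and "the series" means these few. Any claim that something is new, unique, unknown or untested is made for them only; others in the source may bear on it.

Measured compounds:
- Compound 1, `Fc1ccc(-c2csc(N/N=C/c3ccc(Cl)cc3Cl)n2)cc1`: 96%
- Compound 2, `COc1ccc(-c2csc(N/N=C/c3ccc(Cl)cc3Cl)n2)cc1`: 93.3%
- Compound 3, `Clc1ccc(-c2csc(N/N=C/c3ccc(Cl)cc3Cl)n2)cc1`: 92.4%

In a functional assay, read by spectrophotometry, with a stated time of 15 min, tested at 100 ug/mL (a higher number here means a stronger effect of the compound at the concentration tested, a lower number a weaker effect), compound 1 gives 96%, compound 2 gives 93.3% and compound 3 gives 92.4%. Compound 3 stands alongside the other two: the steps of a number 3.6 percentage points lower from compound 1 to compound 3 (within the scatter) and a number 0.9 percentage points lower from compound 2 to compound 3 (within the scatter), like a number 2.7 percentage points lower from compound 1 to compound 2 (within the scatter), are all within the scatter. Every one of these steps is a swap of the substituent on the same aromatic carbon of the shared core, and none of them moves the read-out beyond the scatter.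

Compound 4, `Clc1ccc(/C=N/Nc2nc(-c3ccccc3)cs2)c(Cl)c1`, differs from compound 3 by hydrogen in place of chloro on an aromatic carbon. This is a fourth change at the same position, so the three measured steps bear on it directly, and since each of them was within the scatter, no step beyond the scatter is expected here either. Compound 4 is therefore expected to give about 91%, within 80% to 98%. The estimated step of a number 1.4 percentage points lower from compound 3 to compound 4 (within the scatter) is expected to stay inside the scatter.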

Compound 4, a percentage reported as inhibition, at one concentration (the size of the read-out at that concentration, not a potency): 95.8%
The estimate for compound 4 lay 4.8 percentage points below the measured number, and the stated range covers the measured number.
By their numbers in this assay, from the lowest: compounds 3, 2, 4 and 1 (each within the scatter of the next).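

In this assay, replacing 4-chlorophenyl with phenyl gives the steps of a number 3.4 percentage points higher from compound 3 to compound 4 (within the scatter) and a number 2.5 percentage points higher from compound 2 to compound 4 (within the scatter) and a number 0.2 percentage points lower from compound 1 to compound 4 (within the scatter) without leaving the scatter. The earlier compounds shown here showed only that one substituent on this aromatic carbon could be traded for another; compound 4 adds that, at the concentration tested, the read-out also holds with hydrogen alone at this place. Nothing at hand explains this tolerance.

All four compounds were compared at a single concentration and lie close together, so any differences among them in the strength of the effect at that concentration remain unresolved. Going by these compounds, whether an amine, a carboxylic acid or a longer chain on this carbon would hold the read-out as well also remains open.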